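Chain branching and cytotoxicity in four related compounds

A few compounds are considered here, and "the series" means these few. Any claim that something is new, unique, unknown or untested is made for them only; others in the source may bear on it.

Compound 1 `CCCCNc1cc(Oc2c(OC)cc3cc(C#N)ccc3c2OC)nc(Nc2ccc(C#N)cc2)n1` carries a butyl chain on a nitrogen on an aromatic ring. In an ADME assay on MT4 cells (Homo sapiens) for cytotoxicity, read by MTT assay, with a stated time of 5 days (on this read-out higher numbers stand for lower toxicity in this test and lower numbers for higher toxicity in this test), compound 1 gives > 125000 nM and this is a limit of the assay rather than a number. Compound 2 `CCCCCNc1cc(Oc2c(OC)cc3cc(C#N)ccc3c2OC)nc(Nc2ccc(C#N)cc2)n1` differs from compound 1 by methyl in place of hydrogen on a saturated chain carbon, four bonds along the chain from a nitrogen on an aromatic ring and in this assay compound 2 gives > 125000 nM which is again a limit. Because all values sit at the limit of > 125000 nM in this assay, at which 3 of the 3 values shown sit, the step that the two limits leave unreadable from compound 1 to compound 2 cannot be sized. Compound 3 `CCC(C)Nc1cc(Oc2c(OC)cc3cc(C#N)ccc3c2OC)nc(Nc2ccc(C#N)cc2)n1` differs from compound 1 by sec-butyl in place of butyl on a nitrogen on an aromatic ring and in this assay compound 3 gives > 125000 nM which is also a limit. Compound 4 `CCC(CC)Nc1cc(Oc2c(OC)cc3cc(C#N)ccc3c2OC)nc(Nc2ccc(C#N)cc2)n1` is not yet measured and differs from compound 3 by methyl in place of hydrogen on a saturated chain carbon, two bonds along the chain from a nitrogen on an aromatic ring which is the same kind of change as from compound 1 to compound 2, though placed two bonds along the chain from the nitrogen rather than four bonds along. Because compound 3 sits at the limit of > 125000 nM in this assay, at which 3 of the 3 values shown sit, compound 4 is expected to show a step of a number no higher from compound 3 to compound 4 (the limit leaves the size open) and an estimated value of 125000 nM in this assay.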

Compound 4, half-maximal cytotoxic concentration: > 125000 nM
Compound 4: a limit, no number (the forecaster's own chance of this, stated with the estimate: 85%); the middle value sits exactly at the limit.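

In this assay no step among compound 1, compound 2, compound 3 and compound 4 can be read, because all four values are limits and not numbers: the limit of > 125000 nM in this assay, at which 4 of the 4 values shown sit.

From the compounds shown here alone, whether any of these chains changes the result in this assay at all stays open.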